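The source may report more compounds than this note shows. Statements on the series, on what has been measured and on what is new or still open speak of the compounds shown alone.

Compounds measured so far:
compound 1, `CC/C=C\C/C=C\C/C=C\CCCCCCCc1cc(=O)c2c(O)c(C)c(O)c(C)c2o1`, 17500 nM;
compound 2, `CC/C=C\C/C=C\C/C=C\CCCCCCCc1cc(=O)c2c(O)c(C)c(OCOC)c(C)c2o1`, > 84100 nM, a limit of the assay rather than a number;
compound 3, `CC/C=C\C/C=C\C/C=C\CCCCCCCc1cc(=O)c2c(O)cc(O)c(C)c2o1`, 17500 nM.

In a functional assay on MCF7 cells (Homo sapiens) for antiproliferative activity, read by MTT assay (a higher number here means a weaker inhibitor, a lower number a stronger inhibitor), compound 1 gives 17500 nM, level with compound 3 at the digits shown, no change at the digits printed from compound 1 to compound 3 (within the scatter). Compound 2 sits at the limit of > 84100 nM in this assay, at which 1 of the 3 values shown sits, so an at least 4.8-fold higher number from compound 1 to compound 2 (0.68 log units; beyond the scatter).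

Compound 4, `CCCC/C=C\CCCCCCCCCc1cc(=O)c2c(O)c(C)c(O)c(C)c2o1`, has not yet been measured. It differs from compound 1 on the chain: a group of 8 heavy atoms (8 carbon; no ring) in place of a group of 10 heavy atoms (10 carbon; no ring), on a saturated chain carbon, seven bonds along the chain from an aromatic carbon. Both measured steps alter the aromatic core, not the chain, so neither bears on this change; no precedent for it exists among these compounds. A step of no change beyond the scatter is therefore expected, a 1.1-fold higher number from compound 1 to compound 4 (0.06 log units; within the scatter). Compound 4 is estimated at 20000 nM, within 7000 nM to 55000 nM.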

Compound 4, half-maximal inhibitory concentration: > 67200 nM
Compound 4 ended at the assay's limit (the forecaster's own chance of this, stated with the estimate: 15%); at least 3.3-fold (0.52 log units) between middle value and limit.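

The chain is not a silent position: in this assay, oct-3-en-1-yl in place of the group of 10 heavy atoms gives an at least 3.8-fold higher number from compound 1 to compound 4 (0.58 log units; beyond the scatter). Until now, only a change on the aromatic core had moved the read-out beyond the scatter. The value of compound 4 is a limit of the assay, not a number: the limit of > 67200 nM in this assay, at which 1 of the 4 values shown sits.

This single step alters chain length and the count of double bonds together, and the two cannot be separated here. On these data alone, whether a fully saturated chain or a longer chain carrying the three double bonds would keep the activity of compound 1 remains open.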